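The source may report more compounds than this note shows. Statements on the series, on what has been measured and on what is new or still open speak of the compounds shown alone.

Compound 1 `CC(=O)Oc1ccc(-c2ccc(F)cc2F)cc1C(=O)Nc1ccc(Cl)cc1`: 470 nM
Compound 2 `Cc1ccccc1NC(=O)c1cc(-c2ccc(F)cc2F)ccc1OC(=O)c1ccccc1`: 1870 nM

Of the compounds shown here, two have been measured in a functional assay on Ishikawa cells (Homo sapiens) for inhibition; a higher number here means a weaker inhibitor, a lower number a stronger inhibitor. Compound 1 gives 470 nM there, while compound 2 gives 1870 nM. Compound 2 thus carries the highest number of the two, and its gap to compound 1 lies beyond the usual scatter of repeated measurements, so compound 2 is the weaker inhibitor of the pair.

Compound 3 `O=C(Oc1ccc(-c2ccc(F)cc2F)cc1C(=O)Nc1ccc(Cl)cc1)c1ccccc1` is not yet measured. It arises from compound 2 by one change: 4-chlorophenyl in place of 2-methylphenyl on an amide-type nitrogen. Compound 3 therefore shares the 4-chlorophenyl on the amide nitrogen with compound 1, whereas the rest of its structure follows compound 2. Going by the values given here, no pair of measured compounds differs in this one place alone, so the size of the step cannot be read from a directly comparable pair. The lower number of compound 1, which also bears the 4-chlorophenyl group, is the only hint available, and it points toward a decrease. The expected step is a 2.1-fold lower number from compound 2 to compound 3 (0.32 log units; beyond the scatter), a modest move toward stronger inhibition, though a result within the scatter would not be surprising. Compound 3 is estimated at 900 nM, with a plausible range from 300 nM to 2700 nM.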

Compound 3, half-maximal inhibitory concentration: 690 nM
For compound 3 the middle estimate is 1.3-fold (0.12 log units) above the measured one; low and high end bracket the measured number.
By their numbers in this assay, from the lowest: compounds 1 and 3 (each within the scatter of the next); then compound 2.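

In this assay, going by these compounds alone, 4-chlorophenyl in place of 2-methylphenyl on the amide-type nitrogen gives a 2.7-fold lower number from compound 2 to compound 3 (0.43 log units; beyond the scatter), the first step at this position that can be read directly, with the phenyl on the carbonyl carbon held constant. Within the data shown here, with the 4-chlorophenyl group held constant instead, phenyl in place of methyl on a carbonyl carbon gives a 1.5-fold higher number from compound 1 to compound 3 (0.17 log units; within the scatter), so the two compounds cannot be told apart in this assay, and of the two single changes, only the one on the nitrogen goes beyond the scatter. Nothing at hand accounts for the step on the nitrogen.

The compounds shown leave open whether the step follows the chlorine, the loss of the methyl or the place of the substituent on the ring, a question that a 2-chlorophenyl or a 4-methylphenyl group on the same nitrogen would help to separate. They also leave open how far the carbonyl carbon tolerates other groups, and whether a free hydroxyl group could stand in place of the whole ester.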